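The compounds below may be only part of what the source reports. "The series", "measured", "known", "first", "only" and "open" are said of these compounds alone.

Measured so far:
Compound 1, `Cc1nc(S(C)(=O)=O)ccc1Oc1ncnc(OC2CCN(C(=O)O[C@@H](C)CF)CC2)c1F` — 84%
Compound 2, `Cc1nc(S(C)(=O)=O)ccc1Oc1ncnc(OC2CCN(C(=O)SC3(C)CC3)CC2)c1F` — 77%

Both compounds were tested in a functional assay on isolated protein for inhibition of Glucose-dependent insulinotropic receptor (Rattus norvegicus), read by HTRF and cAMP accumulation; a higher number here means a larger maximal response, a lower number a smaller maximal response. Going by the values given here, compound 2 gives 77%, and compound 1 gives 84%; the only step known so far, a number 7 percentage points lower from compound 1 to compound 2 (within the scatter), is a change on a carbonyl carbon, and its size falls within the scatter, so the two numbers cannot be told apart.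

Compound 3, `Cc1nc(S(C)(=O)=O)ccc1Oc1ncnc(OC2CCN(C(=O)C(F)(F)F)CC2)c1F`, differs from compound 2 in one place: a group of 4 heavy atoms (1 carbon, 3 fluorine; no ring) in place of a group of 5 heavy atoms (4 carbon, 1 sulfur; one three-membered non-aromatic ring of carbon only), on a carbonyl carbon. Among the compounds with values here, this change sits on the same carbonyl carbon as the step from compound 1 to compound 2, which is the only measured step that bears on it, and that step was within the scatter. On this basis no step beyond the scatter is expected here either, so compound 3 is estimated at 80% in this assay, in a range from 65% to 92%, which would mean an expected step of a number 3 percentage points higher from compound 2 to compound 3 (within the scatter).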

Compound 3, largest response reached (reported as efficacy), in percent of the reference or control that the assay uses: 76%
Compound 3: the middle estimate sits 4 percentage points above what was measured; the range from low to high includes it.
By their numbers in this assay, from the lowest: compounds 3, 2 and 1 (each within the scatter of the next).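

In this assay, replacing the group on this carbonyl carbon with trifluoromethyl gives a number 1 percentage points lower from compound 2 to compound 3 (within the scatter) and a number 8 percentage points lower from compound 1 to compound 3 (within the scatter). Where the earlier pair offered a single comparison, three different groups at this place now give numbers that cannot be told apart, and one of them, trifluoromethyl, has no ring and no hydrogen-bond acceptor. No measurement is available to explain this result.

Going by these compounds, whether the maximal response would stay in the same range with an amine, a carboxylic acid or a longer carbon chain on this carbonyl carbon remains open. Also open, on these data alone, is how these three compounds compare in the concentration needed to reach that response, which the largest response alone does not tell.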